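The source may report more compounds than this note shows. Statements on the series, on what has been measured and on what is new or still open speak of the compounds shown alone.

Measured so far:
compound 1 `CC(C)(N)C(=O)N[C@H](COCc1ccccc1)c1nnnn1Cc1ccc(NS(C)(=O)=O)cc1` — > 5000 nM, a limit of the assay
compound 2 `CC(C)(N)C(=O)N[C@H](COCc1ccccc1)c1nnn(Cc2cccc(NS(C)(=O)=O)c2)n1` — > 5000 nM, a limit of the assay
compound 3 `CC(C)(N)C(=O)N[C@H](COCc1ccccc1)c1nnn(Cc2ccccc2NS(C)(=O)=O)n1` — > 5000 nM, a limit of the assay

None of the three readings in an assay on isolated protein for displacement of a labelled ligand from growth hormone secretagogue receptor type 1 (Homo sapiens), with a stated time of 1 h (on this read-out lower numbers stand for stronger inhibition and higher numbers for weaker inhibition), is a number. Compound 1 stands only at the limit, and that is all that can be said of it. For the measured compounds named here, the series as a whole sits at the limit of > 5000 nM in this assay, at which 3 of the 3 values shown sit, so no compound can be placed above or below another.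

Going by the values given here, the one change among measured compounds is a step that the two limits leave unreadable from compound 2 to compound 3. It moves the methanesulfonamido group around its ring and does not touch the group itself, so it bears only loosely on the step to compound 4, and in any case its size is not readable.

Compound 4 `CC(C)(N)C(=O)N[C@H](COCc1ccccc1)c1nnnn1CCC(=O)NCc1ccccc1` has not been measured in this assay. Relative to compound 1 the change is (benzylcarbamoyl)methyl in place of 4-(methanesulfonamido)phenyl on a saturated chain carbon bound to an aromatic nitrogen. Among the compounds with values here, no measured step tells how this assay responds to exchanging the whole substituent on the saturated chain carbon bound to an aromatic nitrogen, so the direction and size of the step are open; the only anchor is that compound 1 gives no number.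

The step expected is a number no higher from compound 1 to compound 4 (the limit leaves the size open). Compound 4 is estimated at 5000 nM, with a range from 800 nM to 20000 nM, and a fair chance that this assay again returns only a limit.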

Compound 4, inhibition constant: 1070 nM
Estimate against measurement, compound 4: 4.7-fold (0.67 log units) above, within the range that was stated.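

Exchanging 4-(methanesulfonamido)phenyl for (benzylcarbamoyl)methyl on a saturated chain carbon bound to an aromatic nitrogen gives an at least 4.6-fold lower number from compound 1 to compound 4 (0.66 log units; beyond the scatter) in this assay. Both groups hold one six-membered aromatic ring of carbon only and the same number of heavy atoms, so neither that ring nor the heavy-atom count separates them, and this place in the series is now shown to respond to the substituent it carries. Compound 4 is the only compound with a number, so the size of the step has only a lower bound: the limit of > 5000 nM in this assay, at which 3 of the 4 values shown sit.

As far as these compounds go, it remains open which part of the (benzylcarbamoyl)methyl group carries the step. Also open, from the compounds shown here alone, is how a longer chain between the amide and the phenyl ring, or a carboxylic acid or an amine in place of the benzyl amide, would read in this assay.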